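Working notes: sulfonyl-aryl exchange from compound 1 to compound 4

The source may report more compounds than this note shows. Statements on the series, on what has been measured and on what is new or still open speak of the compounds shown alone.

For the measured compounds named here, in an assay on cells for inhibition of HSP60/HSP10 (Homo sapiens), with a stated time of 60 min (a higher number here means a weaker inhibitor, a lower number a stronger inhibitor), compound 1 `O=S(=O)(Nc1ccc(-c2nc3ccccc3o2)cc1)c1ccc(Cl)s1` gives 31000 nM, the only numeric value in this small set. Compound 2 `O=S(=O)(Nc1ccc2oc(-c3ccccc3)nc2c1)c1cccc(F)c1` sits at the assay limit, > 100000 nM. Compound 3 `COc1ccccc1S(=O)(=O)Nc1ccc2oc(-c3ccccc3)nc2c1` likewise sits at the assay limit, > 100000 nM. Going by the values given here, the single measured step, a step that the two limits leave unreadable from compound 2 to compound 3, is unreadable because the limit of > 100000 nM in this assay, at which 2 of the 3 values shown sit, hides both of its ends. Compound 4 `O=S(=O)(Nc1ccc(-c2nc3ccccc3o2)cc1)c1ccccc1O` differs from compound 1 by 2-hydroxyphenyl in place of 5-chlorothiophen-2-yl on a sulfonyl sulfur. Among the compounds with values here, no measured step covers an exchange of this kind on the sulfonyl sulfur, so the direction in this assay is open. The expected step of a 1.5-fold higher number from compound 1 to compound 4 (0.16 log units; within the scatter) is taken as small, within the scatter, with a real chance of falling to the limit. Compound 4 is therefore estimated at 45000 nM, range 15000 nM to 150000 nM.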

Compound 4, half-maximal inhibitory concentration: > 100000 nM
Compound 4 gave a limit, no number; the forecaster's own chance of this, stated with the estimate: 35%; middle value at least 2.2-fold (0.34 log units) from the limit.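

For the compounds shown here, on the sulfonyl sulfur, 2-hydroxyphenyl in place of 5-chlorothiophen-2-yl gives an at least 3.2-fold higher number from compound 1 to compound 4 (0.50 log units; beyond the scatter), the first readable step at this position in this assay, and it shows that this position does not accept every aryl exchange without loss. Compound 4 stands at a limit, > 100000 nM, not at a number. The step therefore gives a direction and a minimum size only, and the true size stays hidden: the limit of > 100000 nM in this assay, at which 3 of the 4 values shown sit.

The compounds shown do not separate the departure of 5-chlorothiophen-2-yl from the arrival of 2-hydroxyphenyl. On these data alone, whether a thiophen-2-yl without the chlorine, or a phenyl ring carrying an amine, would hold the inhibition of compound 1 remains open.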